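This account rests on a few compounds, and the source may have more. Where it says the series, first, only, none or still open, it means among the compounds named here.

Working notes on the series. Compound 3 `CC1CCC(=NNc2c(Cl)cccc2Cl)c2ncc(C(=O)O)c(=O)n21` carries the shared core with a 2,6-dichlorophenyl on the amine nitrogen. In a functional assay on the whole organism with Rattus norvegicus as the target (on this read-out lower numbers stand for an effect already at smaller amounts and higher numbers for an effect only at larger amounts of compound), compound 3 gives > 100 umol/kg, which is a limit of the assay and not a number. Compound 1 `Cc1ccc(NN=C2CCC(C)n3c2ncc(C(=O)O)c3=O)cc1C` gives > 100 umol/kg in this assay, likewise a limit. Compound 2 `CC1CCC(=NNc2ccc(Cl)cc2Cl)c2ncc(C(=O)O)c(=O)n21` gives > 100 umol/kg in this assay, again a limit. All three values therefore sit at the limit of > 100 umol/kg in this assay, at which 3 of the 3 values shown sit, and the steps a step that the two limits leave unreadable from compound 1 to compound 2, a step that the two limits leave unreadable from compound 1 to compound 3 and a step that the two limits leave unreadable from compound 2 to compound 3 have no readable size or direction.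

Compound 4 `CC1CCC(=NNc2ccc(Br)cc2Cl)c2ncc(C(=O)O)c(=O)n21` differs from compound 3 by 4-bromo-2-chlorophenyl in place of 2,6-dichlorophenyl on an amine nitrogen. The measured steps that bear on this change are the three exchanges of the aryl group on the amine nitrogen, and each of them is left unreadable by the limits; they give no basis to expect a step beyond the scatter in either direction. The step that the limit leaves unreadable from compound 3 to compound 4 is thus expected to be small. For compound 4 the expected value in this assay is 150 umol/kg, with a range from 50 umol/kg to 500 umol/kg, most probably reported again as a limit.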

Compound 4, dose for 50% inhibition: > 100 umol/kg
Compound 4 gave a limit, no number; the forecaster's own chance of this, stated with the estimate: 70%; the middle value is on the limit's open side.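

Within the data shown here, compound 4 also gives only a limit, so no step among compound 1, compound 2, compound 3 and compound 4 can be read in this assay: the limit of > 100 umol/kg in this assay, at which 4 of the 4 values shown sit. The compounds shown leave open whether any aryl group on the amine nitrogen of the shared core gives a readable number on this read-out.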